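A few compounds are considered here, and "the series" means these few. Any claim that something is new, unique, unknown or untested is made for them only; others in the source may bear on it.

Compound 1 `C#CCN1CCC(OC(=O)Nc2ccc(C(C)C)cc2)CC1` and compound 2 `C#CCN1CCCC(COC(=O)N(C)CC)C1` were both run in an assay on BTI-TN-5B1-4 cells for inhibition of Amine oxidase [flavin-containing] A (Homo sapiens), read by fluorescence and Amplex Red, using microsomes, with a stated time of 15 min; on this read-out lower numbers stand for stronger inhibition and higher numbers for weaker inhibition. In this assay compound 1 returns only > 100000 nM, a limit of the assay rather than a number. Compound 2 in turn gives only > 100000 nM in this assay, again a limit and not a number. Where compound 2 stands is therefore set by the limit of > 100000 nM in this assay, at which 2 of the 2 values shown sit, alone. Compound 3 `CCN(C)C(=O)OCC1CCCN(Cc2ccccc2)C1` differs from compound 2 by phenyl in place of ethynyl on a saturated chain carbon bound to an amine nitrogen in a ring. Among the measured compounds shown here, with no measured step to lean on, the step from compound 2 to compound 3 is expected to be a number no higher from compound 2 to compound 3 (the limit leaves the size open), nothing beyond the scatter. Compound 3 is estimated at 100000 nM, between 30000 nM and 300000 nM, most likely again reported only as a limit.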

Compound 3, half-maximal inhibitory concentration: > 100000 nM
Compound 3: only a limit was reported; the forecaster's own chance of this, stated with the estimate: 80%; the middle value sits exactly at the limit.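

In this assay compound 3 gives > 100000 nM, a limit and not a number. Among the compounds shown here, with compound 2 also at a limit, no step between compound 2 and compound 3 can be read. The compounds shown leave open which change, if any, would bring a measurable value in this assay.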